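The compounds below may be only part of what the source reports. "The series", "measured", "known", "first", "only" and "open" are said of these compounds alone.

Three compounds that share one core and differ in the group on an amine nitrogen have been tested in a functional assay on Caco-2 cells (Homo sapiens) for inhibition, read by MTT assay, with a stated time of 72 h; a higher number here means a weaker inhibitor, a lower number a stronger inhibitor: compound 1 `CCCNC(=C\C(=O)/C=C/c1ccc(O)c(OC)c1)/C=C/c1ccc(O)c(OC)c1`, compound 2 `CCC(C)NC(=C\C(=O)/C=C/c1ccc(O)c(OC)c1)/C=C/c1ccc(O)c(OC)c1` and compound 3 `COc1cc(/C=C/C(=O)/C=C(/C=C/c2ccc(O)c(OC)c2)NC2CCCCC2)ccc1O`. Compound 1 gives > 25000 nM, which is a limit of the assay. Compound 2 gives > 25000 nM, also a limit. Compound 3 gives > 25000 nM, again a limit and not a number. Compound 3 therefore has no exact place on the scale and stands with the other two at the limit of > 25000 nM in this assay, at which 3 of the 3 values shown sit.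

Compound 4 `COc1cc(/C=C/C(=O)/C=C(/C=C/c2ccc(O)c(OC)c2)NCC(C)C)ccc1O` changes that same group: isobutyl in place of cyclohexyl on an amine nitrogen. The closest evidence is a step that the two limits leave unreadable from compound 2 to compound 3 and a step that the two limits leave unreadable from compound 1 to compound 3, and a step that the two limits leave unreadable from compound 1 to compound 2 also bears on it. None of these gives a size, yet all three compounds end at the same limit. No step beyond the scatter is therefore expected in this assay, in either direction, and the expected step that the limit leaves unreadable from compound 3 to compound 4 is only nominal. For compound 4 the estimate is 30000 nM, with an expected range from 12000 nM to 60000 nM. Most likely the assay will again report only a limit.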

Compound 4, half-maximal inhibitory concentration: > 25000 nM
Compound 4 gave a limit, no number; the forecaster's own chance of this, stated with the estimate: 85%; the middle value lies beyond the limit too.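

Compound 4 also ends at a limit and not a number, so no step can be read between it and compound 1, compound 2 or compound 3 in this assay: the limit of > 25000 nM in this assay, at which 4 of the 4 values shown sit. The compounds shown leave open whether the group on the amine nitrogen affects inhibition at all.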